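The source may hold more compounds than are shown below. What is called first, only, known or untested is meant among the compounds shown, and "the series" means these compounds.

Measured compounds:
Compound 1, `CCCc1ccccc1OS(=O)(=O)c1cccc(NC(=O)NCCCCl)c1`: 15000 nM
Compound 2, `O=C(NCCCCl)Nc1cccc(S(=O)(=O)Oc2ccc(O)cc2)c1`: 49000 nM
Compound 3, `CCCc1ccccc1OS(=O)(=O)c1ccc(NC(=O)NCCCCl)cc1`: 13000 nM

All three were tested in a functional assay on M21 cells (Homo sapiens) for cytotoxicity, read by sulforhodamine B assay, with a stated time of 48 h; on this read-out higher numbers stand for weaker inhibition and lower numbers for stronger inhibition. Compound 1 and compound 3 are built from the same atoms joined differently; the difference between the two cores is not broken down here. Their values in this assay lie within the scatter of each other, so neither can be placed ahead of the other. Compound 2 differs from compound 1 in one place: 4-hydroxyphenyl in place of 2-propylphenyl on an oxygen. That change gave a 3.3-fold higher number from compound 1 to compound 2 (0.51 log units; beyond the scatter).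

Compound 4, `O=C(NCCCCl)Nc1ccc(S(=O)(=O)Oc2ccc(O)cc2)cc1`, has not yet been tested in this assay. It carries the same change, made on the core of compound 3: 4-hydroxyphenyl in place of 2-propylphenyl on an oxygen. The place is the same in both cases, so this is the same change, not merely the same kind. Going by the values given here, only one earlier example exists, so the expectation rests on that step alone, starting from compound 3 at 13000 nM. The step is expected to be a 3.3-fold higher number from compound 3 to compound 4 (0.52 log units; beyond the scatter), matching the earlier one in size. For compound 4 the estimate is 43000 nM, with a range from 20000 nM to 90000 nM.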

Compound 4, half-maximal inhibitory concentration: 47000 nM
For compound 4 the middle estimate is 1.1-fold (0.04 log units) below the measured one, within the range that was stated.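

In this assay, putting 4-hydroxyphenyl in place of 2-propylphenyl on the oxygen held by the sulfonyl sulfur gave a 3.6-fold higher number from compound 3 to compound 4 (0.56 log units; beyond the scatter). Set beside the earlier case, the change carried over from one core to the other with its size kept: the same change on two cores in this assay, a 3.3-fold higher number (0.51 log units; beyond the scatter) from compound 1 to compound 2 and a 3.6-fold higher number (0.56 log units; beyond the scatter) from compound 3 to compound 4, 1.1-fold (0.04 log units) apart, within the scatter of two such steps. This shows that the change behaved alike on these two cores, which are built from the same atoms joined differently, but it does not show that it would do so on any further core, and it gives no reason for the weaker inhibition.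

The compounds shown leave open which part of the swap matters, the loss of the propyl chain or the gain of the hydroxyl, and a plain phenyl group on the same oxygen, or an amine or methoxy group in place of the hydroxyl, would help to separate the two. They also leave open how the numbers would respond to a longer chain in place of the chlorine-bearing chain.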